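Chloro for cyano on the phenylurea of compound 2

The source may report more compounds than this note shows. Statements on the series, on what has been measured and on what is new or still open speak of the compounds shown alone.

Two compounds of this series have numbers in an assay on isolated protein for inhibition of Dihydrofolate reductase (Mus musculus); on this read-out higher numbers stand for higher potency (the scale is a negative logarithm) and lower numbers for lower potency. Compound 1 `CC1(C)N=C(N)N=C(N)N1c1ccc(SCC(=O)Nc2ccc(S(=O)(=O)F)cc2)cc1` gives 7.52. Compound 2 `CC1(C)N=C(N)N=C(N)N1c1cccc(CNC(=O)Nc2cccc(C#N)c2)c1` gives 8.19 and stands highest of the two; its nearest neighbour is compound 1, whose number is lower by more than the usual scatter. For the measured compounds named here, no pair of measured compounds differs in only one place, so the series itself offers no measured step against which a single substituent exchange can be sized.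

Compound 3 `CC1(C)N=C(N)N=C(N)N1c1cccc(CNC(=O)Nc2cccc(Cl)c2)c1` has not yet been measured in this assay. It differs from compound 2 by chloro in place of cyano on an aromatic carbon, an exchange of one small aromatic substituent for another on the same ring position. Without a measured step of this kind, the expected change from compound 2 to compound 3 is put at a number 0.09 log units lower from compound 2 to compound 3 (within the scatter), not beyond the scatter in either direction. Compound 3 is accordingly estimated at 8.1, with a range from 7.5 to 8.7.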

Compound 3, logarithm of the reciprocal of the active concentration, log(1/C): 8.05
Compound 3: middle estimate off by 0.05 log units, on the high side, and the stated range covers the measured number.
By their numbers in this assay, from the lowest: compound 1; then compounds 3 and 2 (each within the scatter of the next).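

For the compounds shown here, the first single-place step reads, in this assay, a number 0.14 log units lower from compound 2 to compound 3 (within the scatter), for chloro in place of cyano on an aromatic carbon. At this place, the 3-cyanophenyl and 3-chlorophenyl compounds cannot be told apart on this read-out, although the entering group has one heavy atom against two and no hydrogen-bond acceptor against one, and the triple bond outside aromatic rings is gone. No measurement is available that bears on why the two numbers lie so close.

Still open, going by these compounds, is whether the number stays within the scatter with a group of another kind at this place, such as an amine, a carboxylic acid or a longer alkyl chain. A single step also leaves open whether chloro for cyano reads the same on a compound with a different link between the phenyl ring and the shared core.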